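Isobutyl for Isopropyl on the Amide Nitrogen

The compounds below may be only part of what the source reports. "The series", "measured", "known", "first", "only" and "open" are said of these compounds alone.

For the measured compounds named here, compound 3 `CC[C@@H]1C(=O)N(C)c2cnc(-n3ccc4cc(C(=O)NC(C)C)ccc43)nc2N1C1CCCC1` gives 17.4 nM in an assay for inhibition of serine/threonine-protein kinase PLK2 (Homo sapiens), read by FRET and Z'-LYTE, with a stated time of 1 h (on this read-out lower numbers stand for stronger inhibition and higher numbers for weaker inhibition), the lowest of the three numbers measured so far. Compound 2 `CCCCNS(=O)(=O)c1ccc(Nc2ncc3c(n2)N(c2ccn(C)n2)C(CC)C(=O)N3C)cc1` gives 191 nM, and compound 1 `CC[C@@H]1C(=O)N(C)c2cnc(-n3ccc4ccccc43)nc2N1C1CCCC1` gives 355 nM. The step of a 20-fold lower number from compound 1 to compound 3 (1.31 log units; beyond the scatter) shows what the isopropylcarbamoyl group brings. Compound 4 `CC[C@@H]1C(=O)N(C)c2cnc(-n3ccc4cc(C(=O)NCC(C)C)ccc43)nc2N1C1CCCC1` differs from compound 3 only by isobutyl in place of isopropyl on an amide-type nitrogen. Going by the values given here, no measured step varies the alkyl on this nitrogen; the one step available concerns adding the whole group rather than altering its size, so nothing here points to a shift beyond the scatter in either direction. For compound 4 the expected change is a 1.1-fold higher number from compound 3 to compound 4 (0.06 log units; within the scatter), essentially flat. The estimate for compound 4 is 20 nM, with a range from 8 nM to 50 nM.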

Compound 4, half-maximal inhibitory concentration: 18.6 nM
Estimate against measurement, compound 4: 1.1-fold (0.03 log units) above; low and high end bracket the measured number.
By their numbers in this assay, from the lowest: compounds 3 and 4 (each within the scatter of the next); then compounds 2 and 1 (each within the scatter of the next).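

In this assay, isobutyl in place of isopropyl on the amide-type nitrogen gives a 1.1-fold higher number from compound 3 to compound 4 (0.03 log units; within the scatter), so this nitrogen carries either alkyl group without a change beyond the scatter. Isobutylcarbamoyl in place of hydrogen on an aromatic carbon gives a 19-fold lower number from compound 1 to compound 4 (1.28 log units; beyond the scatter), so the large step is not confined to the isopropylcarbamoyl group. No evidence on hand bears on this result.

Still open, going by these compounds, is how a longer chain, such as n-hexyl, or a cyclohexyl ring would read on this nitrogen. Also open, on these data alone, is whether a chain ending in an amine or a carboxylic acid would hold the number.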